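Expected cytotoxicity after a methylsulfanyl to pyridinyloxy change

The source may hold more compounds than are shown below. What is called first, only, known or untested is meant among the compounds shown, and "the series" means these compounds.

Measured compounds:
compound 1, `CSCc1ccc(Nc2ncc(Cc3c(F)cccc3F)o2)cc1`: in an ADME assay on MT2 cells (Homo sapiens) for cytotoxicity, read by MTT assay (on this read-out higher numbers stand for lower toxicity in this test and lower numbers for higher toxicity in this test), compound 1 gives > 100000 nM
compound 2, `Clc1cccc(Cl)c1Cc1nnc(Nc2ccc(COCc3cccnc3)cc2)o1`: compound 2 gives 81000 nM
compound 3, `Fc1cccc(F)c1Cc1cnc(Nc2ccc(-c3cccnc3)c(Cl)c2)o1`: compound 3 gives 8900 nM

Compound 1 stands only at a limit of this assay and not at a number, as shown by the limit of > 100000 nM in this assay, at which 1 of the 3 values shown sits. Compound 4, `Fc1cccc(F)c1Cc1cnc(Nc2ccc(COc3ccncc3)cc2)o1`, differs from compound 1 by (pyridin-4-yl)oxy in place of methylsulfanyl on a saturated chain carbon bound to an aromatic carbon. Within the data shown here, no step between two measured compounds is available here, so nothing measured speaks directly for this change; the values of compound 2 and compound 3 merely show that numbers below the limit of compound 1 occur. The step of an at least 2.0-fold lower number from compound 1 to compound 4 (0.30 log units; that floor lies within the scatter) is expected to be a modest move toward higher toxicity in this assay, somewhat beyond the scatter. Compound 4 is therefore estimated to give 50000 nM, with a range from 15000 nM to 150000 nM.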

Compound 4, half-maximal cytotoxic concentration: > 100000 nM
Compound 4: no number, only a limit (the forecaster's own chance of this, stated with the estimate: 30%); middle value at least 2.0-fold (0.30 log units) away from the limit.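

No step can be read from compound 1 to compound 4, as both stand only at a limit in this assay: the limit of > 100000 nM in this assay, at which 2 of the 4 values shown sit.

The compounds shown leave open whether (pyridin-4-yl)oxy in place of methylsulfanyl changes the half-maximal cytotoxic concentration at all.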